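The compounds below may be only part of what the source reports. "The series", "measured", "known", "first", "only" and "open" are said of these compounds alone.

Measured compounds:
compound 1 `N#Cc1ccc(Cn2cc(COc3ccc4c(=O)ccoc4c3)nn2)cc1`: in a functional assay on A549 cells (Homo sapiens) for cytotoxicity, read by MTT assay, with a stated time of 48 h (a higher number here means a weaker inhibitor, a lower number a stronger inhibitor), compound 1 gives > 100000 nM, a limit of the assay.
compound 2 `O=c1ccoc2cc(OCc3cn(Cc4ccccc4Br)nn3)ccc12`: compound 2 gives > 100000 nM, likewise a limit of the assay.
compound 3 `O=c1ccoc2cc(OCc3cn(Cc4ccc(Cl)cc4Cl)nn3)ccc12`: compound 3 gives 5260 nM.

Going by the values given here, compound 3 thus holds the only number in the set; the other two values sit at the limit of > 100000 nM in this assay, at which 2 of the 3 values shown sit. Read from those limits, the steps are an at least 19-fold lower number from compound 1 to compound 3 (1.27 log units; beyond the scatter) and an at least 19-fold lower number from compound 2 to compound 3 (1.27 log units; beyond the scatter), both large, whereas the remaining pair shows only a step that the two limits leave unreadable from compound 1 to compound 2.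

Compound 4 `O=c1ccoc2cc(OCc3cn(Cc4cccc([N+](=O)[O-])c4)nn3)ccc12` is not yet measured. It differs from compound 3 by 3-nitrophenyl in place of 2,4-dichlorophenyl on a saturated chain carbon bound to an aromatic nitrogen. Among the compounds with values here, no measured step exchanges the 2,4-dichlorophenyl for a nitro-bearing ring, so the size of this step has no direct anchor. What the data do show is that the two compounds carrying a group other than 2,4-dichlorophenyl on this carbon, compound 1 and compound 2, both reach only the limit, while compound 3 alone yields a number. On that basis a weakening is expected in this assay, of uncertain size. Compound 4 is expected near 30000 nM, within 6000 nM to 100000 nM. The expected step is a 5.7-fold higher number from compound 3 to compound 4 (0.76 log units; beyond the scatter), with a substantial chance that the assay returns only a limit.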

Compound 4, half-maximal inhibitory concentration: 9450 nM
For compound 4 the middle estimate is 3.2-fold (0.50 log units) above the measured one, within the range that was stated.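

In this assay, a readable number is not confined to the 2,4-dichlorophenyl on a saturated chain carbon bound to an aromatic nitrogen: exchanging it for 3-nitrophenyl gives a 1.8-fold higher number from compound 3 to compound 4 (0.25 log units; within the scatter), so these two groups cannot be told apart in this assay. The 3-nitrophenyl also separates from the two groups that gave no number, with an at least 10-fold lower number from compound 2 to compound 4 (1.02 log units; beyond the scatter) and an at least 10-fold lower number from compound 1 to compound 4 (1.02 log units; beyond the scatter). Chlorine is therefore not required for a number at this position, although not every substituted ring gives one, as the 2-bromophenyl of compound 2 and the 4-cyanophenyl of compound 1 stand against any broader pattern, and these last two steps are minimum sizes set by limits of the assay: the limit of > 100000 nM in this assay, at which 2 of the 4 values shown sit.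

Still open, from the compounds shown here alone, is what an unsubstituted phenyl, or a ring carrying an amine or a carboxylic acid in place of the nitro group, would give in this assay. Also open, going by these compounds, are the effects of a nitro group elsewhere on the ring and of a longer chain in place of the single saturated carbon that joins the ring to the aromatic nitrogen.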